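Trading a carbamate tail for a branched hydroxyl arm

The compounds below may be only part of what the source reports. "The series", "measured", "known", "first", "only" and "open" are said of these compounds alone.

Measured so far in a functional assay on BXPC-3 cells (Homo sapiens) for antiproliferative activity, read by MTT assay, with a stated time of 24 h; on this read-out higher numbers stand for weaker inhibition and lower numbers for stronger inhibition:
compound 1 `CCn1c(C(=O)N[C@@H](C)C(=O)OC)ccc1C(CC)(CC)c1ccc(OCS(=O)(=O)c2ccccc2)c(C)c1` gives 17900 nM
compound 3 `CCn1c(C(=O)N[C@@H](C)CO)ccc1C(CC)(CC)c1ccc(OCS(=O)(=O)c2ccccc2)c(C)c1` gives 15300 nM
compound 2 `CCn1c(C(=O)NCCNC(=O)OC(C)(C)C)ccc1C(CC)(CC)c1ccc(OCS(=O)(=O)c2ccccc2)c(C)c1` gives only a limit, > 50000 nM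

Compound 2 sits at the weak end of these numbers: its value is a limit of the assay, (the limit of > 50000 nM in this assay, at which 1 of the 3 values shown sits). Compound 4 `CCn1c(C(=O)N[C@@H](CO)C(C)C)ccc1C(CC)(CC)c1ccc(OCS(=O)(=O)c2ccccc2)c(C)c1` differs from compound 2 in one place: 1-(hydroxymethyl)-2-methylpropyl in place of 2-((tert-butoxycarbonyl)amino)ethyl on an amide-type nitrogen. The closest measured step is an at least 3.2-fold lower number from compound 2 to compound 3 (0.51 log units; beyond the scatter), where a hydroxymethyl-bearing group replaced the same carbamate tail, and a 1.2-fold lower number from compound 1 to compound 3 (0.07 log units; within the scatter) shows that the hydroxymethyl and methoxycarbonyl variants sit together. A downward step of similar size is therefore expected here. Compound 4 is estimated at 18000 nM, within a range of 8000 nM to 45000 nM. This estimate for compound 4 means an expected at least 2.7-fold lower number from compound 2 to compound 4 (0.44 log units; beyond the scatter).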

Compound 4, half-maximal inhibitory concentration: 13200 nM
Compound 4: middle estimate off by 1.4-fold (0.13 log units), on the high side, within the range that was stated.
By their numbers in this assay, from the lowest: compounds 4, 3 and 1 (each within the scatter of the next). At a limit, above all of these: compound 2.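

Compound 2 is a limit of the assay, not a number: the limit of > 50000 nM in this assay, at which 1 of the 4 values shown sits. A second hydroxyl-bearing branch, 1-(hydroxymethyl)-2-methylpropyl, also gives a clear drop from that limit, with an at least 3.7-fold lower number from compound 2 to compound 4 (0.57 log units; beyond the scatter). Against the other two arms the same branch shows no readable change, with a 1.2-fold lower number from compound 3 to compound 4 (0.06 log units; within the scatter) and a 1.4-fold lower number from compound 1 to compound 4 (0.13 log units; within the scatter), so swapping among these three arms leaves the numbers within the scatter.

Going by these compounds, whether an arm ending in a free amine or a carboxylic acid would sit with these three stays open. So does whether the carbamate or the unbranched ethyl chain sets compound 2 apart.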